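Removing the tert-butyl group from compound 2

This account rests on a few compounds, and the source may have more. Where it says the series, first, only, none or still open, it means among the compounds named here.

In a functional assay on A549 cells (Homo sapiens) for inhibition, read by MTT assay, with a stated time of 72 h (a lower number here means a stronger inhibitor, a higher number a weaker inhibitor), compound 1 `Cc1ccc(-c2nnc(SCCCN3CCN(c4nc5ccccc5s4)CC3)o2)cc1` gives 53900 nM and compound 2 `CC(C)(C)Oc1ccc(-c2nnc(SCCCN3CCN(c4nc5ccccc5s4)CC3)o2)cc1` gives 71600 nM. These two numbers lie within the usual scatter of each other, so compound 2 cannot be ranked against compound 1. For the measured compounds named here, both are the only measured compounds so far.

Compound 3 `Oc1ccc(-c2nnc(SCCCN3CCN(c4nc5ccccc5s4)CC3)o2)cc1` has not yet been measured. Its structure differs from that of compound 2 in one place: hydrogen in place of tert-butyl on an oxygen on an aromatic ring. Put simply, this is hydrogen in place of tert-butyl on an oxygen on an aromatic ring, which turns tert-butoxy into hydroxy.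

Going by the values given here, only one measured step bears on this change: a 1.3-fold higher number from compound 1 to compound 2 (0.12 log units; within the scatter), where tert-butoxy took the place of methyl on an aromatic carbon. Among the compounds with values here, that step gives no sign that this group moves the number much, but no measured compound carries a hydroxy, so the guidance is limited. No step beyond the scatter is therefore expected in this assay, and the estimated step is a 1.2-fold lower number from compound 2 to compound 3 (0.08 log units; within the scatter). For compound 3 the expected value is 60000 nM, with an estimated range from 25000 nM to 130000 nM.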

Compound 3, half-maximal inhibitory concentration: 62100 nM
Compound 3: the middle estimate sits 1.0-fold (0.01 log units) below what was measured; low and high end bracket the measured number.
By their numbers in this assay, from the lowest: compounds 1, 3 and 2 (each within the scatter of the next).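

In this assay taking the tert-butyl group off the oxygen gives a 1.2-fold lower number from compound 2 to compound 3 (0.06 log units; within the scatter) and hydroxy in place of methyl gives a 1.2-fold higher number from compound 1 to compound 3 (0.06 log units; within the scatter) and so neither step separates the compounds. The earlier pair compared only methyl with tert-butoxy; now hydroxy joins them, and the loss of all 4 carbon atoms of the tert-butyl group leaves compound 3 indistinguishable from compound 2 in this assay. Across these three compounds, then, the choice among methyl, tert-butoxy and hydroxy in this place makes no readable difference, though three groups are too few to call the place insensitive to every change. No further data bear on why these numbers fall so close together.

As far as these compounds go, whether some other group in this place would stand apart from these three remains open, and an amine, a carboxylic acid or a chlorine atom would each be a useful test of that. These compounds also leave open whether the same picture would hold if the shared core were altered at the same time.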